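A few compounds are considered here, and "the series" means these few. Any claim that something is new, unique, unknown or untested is made for them only; others in the source may bear on it.

The study begins with compound 1 `O=C(Nc1cccc(-n2cc(-c3ccncc3)c(-c3cc(O)cc(Cl)c3)n2)c1)Nc1ccc(Cl)c(C(F)(F)F)c1`. In a functional assay on M14 cells (Homo sapiens) for inhibition, read by sulforhodamine B assay, with a stated time of 48 h, tested at 0.01 uM (on this read-out higher numbers stand for a weaker effect at the one concentration tested and lower numbers for a stronger effect), compound 1 gives 97%. Compound 2 `COc1cc(Cl)cc(-c2nn(-c3cccc(NC(=O)Nc4ccc(Cl)c(C(F)(F)F)c4)c3)cc2-c2ccncc2)c1` carries a methyl in place of hydrogen on an oxygen on an aromatic ring, and in this assay compound 2 gives 97%; the step of no change at the digits printed from compound 1 to compound 2 (within the scatter). Compound 3 `COc1cc(Cl)cc(-c2nn(-c3cccc(NC(=O)Nc4cc(C(F)(F)F)cc(C(F)(F)F)c4)c3)cc2-c2ccncc2)c1` gives 96% in this assay. On these numbers compound 2 stands level with compound 1, the two together making up the highest readings of the three, while compound 3 lies within the scatter of both.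

The next compound, compound 4 `COc1cc(Cl)cc(-c2nn(-c3cccc(NC(=O)c4cccc(C(F)(F)F)c4)c3)cc2-c2ccncc2)c1`, is compared against compound 2. The change is 3-(trifluoromethyl)phenyl in place of (4-chloro-3-(trifluoromethyl)phenyl)amino on a carbonyl carbon. Going by the values given here, no measured step bears directly on this change: the single step known, from compound 1 to compound 2, concerns another place in the molecule and was flat. Among the compounds with values here, all three measured compounds sit near the same high reading, which leaves little room for any upward movement, and the present replacement has no precedent among them. Compound 4 is therefore expected to show a step of a number 2 percentage points lower from compound 2 to compound 4 (within the scatter), that is, none beyond the scatter. The estimate for compound 4 is 95%, with a range from 82% to 102%.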

Compound 4, a percentage reported as activity, at one concentration (the size of the read-out at that concentration, not a potency): 101%
Compound 4: the middle estimate sits 6 percentage points below what was measured; the range from low to high includes it.
By their numbers in this assay, from the lowest: compounds 3, 1, 2 and 4 (each within the scatter of the next).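

The carbonyl carbon is a place the earlier step did not touch, and in this assay the exchange of (4-chloro-3-(trifluoromethyl)phenyl)amino for 3-(trifluoromethyl)phenyl there gives a number 4 percentage points higher from compound 2 to compound 4 (within the scatter). So this read-out does not separate the two groups, even though the exchange removes the amino nitrogen with its hydrogen-bond donor, and the chlorine with it, and thus turns the linkage on this carbonyl into a different one while the rest of the molecule stays the same. Nothing available explains this result or says what it rests on.

All the readings shown lie together at the one concentration tested, so the compounds leave open whether the two groups would differ under conditions where an effect can be read, and whether the loss of the nitrogen and the loss of the chlorine would each look the same taken alone. They also leave open what a piperidine, a short alkyl chain or a benzyl group on the same carbonyl carbon would give.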